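Side chain extension from compound 2

The source may report more compounds than this note shows. Statements on the series, on what has been measured and on what is new or still open speak of the compounds shown alone.

- compound 1 `CCN1CCN(c2cc(C)c3cc(NC(=O)c4ccc(C)cc4)ccc3n2)CC1`: 11400 nM
- compound 2 `CNc1cc(C)c2cc(NC(=O)c3ccc(Cl)c(Cl)c3)ccc2n1`: 6350 nM
- compound 3 `CCN1CCN(c2cc(C)c3cc(NC(=O)c4cc(Cl)cc(Cl)c4)ccc3n2)CC1`: 2660 nM

In a functional assay on SK-BR-3 cells (Homo sapiens) for antiproliferative activity, read by MTT assay, with a stated time of 72 h (a lower number here means a stronger inhibitor, a higher number a weaker inhibitor), compound 2 stands within the scatter of compound 1, while compound 3 has a lower number, by a gap beyond the scatter. Compound 4 `Cc1cc(NCCN2CCCC2)nc2ccc(NC(=O)c3ccc(Cl)c(Cl)c3)cc12` is reached from compound 2 by (pyrrolidin-1-yl)methyl in place of hydrogen on a saturated chain carbon bound to a nitrogen on an aromatic ring. The same difference reads as methylamino to (2-(pyrrolidin-1-yl)ethyl)amino. For the measured compounds named here, no measured step changes this group. Going by the values given here, the only step, a 4.3-fold lower number from compound 1 to compound 3 (0.63 log units; beyond the scatter), is a change on a carbonyl carbon and bears on the question only indirectly. Compound 3, at 2660 nM, also carries something larger than the methylamino of compound 2, but it differs from compound 4 on the carbonyl carbon as well, so it is a loose guide. A modest shift to a lower number in this assay is therefore expected, with wide uncertainty. The expected step is a 2.1-fold lower number from compound 2 to compound 4 (0.33 log units; beyond the scatter). For compound 4 the estimated value is 3000 nM, with an expected range from 1000 nM to 9000 nM.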

Compound 4, half-maximal inhibitory concentration: 9530 nM
Compound 4: the middle estimate sits 3.2-fold (0.50 log units) below what was measured; measured number outside the range, above it.
By their numbers in this assay, from the lowest: compound 3; then compounds 2, 4 and 1 (each within the scatter of the next).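

In this assay, for the compounds shown here, replacing methylamino with (2-(pyrrolidin-1-yl)ethyl)amino gives a 1.5-fold higher number from compound 2 to compound 4 (0.18 log units; within the scatter), the first reading of a change at this position with the rest of the molecule held constant. This places a (pyrrolidin-1-yl)methyl group, with its five-membered non-aromatic ring, on the saturated chain carbon bound to a nitrogen on an aromatic ring, without a separation beyond the scatter. No measurement here accounts for this outcome.

Still open, going by these compounds, is whether a morpholine or a dimethylamine at the end of the chain, or a longer chain such as 3-(pyrrolidin-1-yl)propyl, would separate from compound 2. Also open, on these data alone, is whether the 2-(pyrrolidin-1-yl)ethyl chain reads the same with the 3,5-dichlorophenyl group of compound 3 on the carbonyl carbon.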